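Replacing the amide nitrogen with an aryl ketone

The source may report more compounds than this note shows. Statements on the series, on what has been measured and on what is new or still open speak of the compounds shown alone.

Compound 1 `NNC(=O)c1c(N)sc2c1CCCCCC2`: 48%
Compound 2 `Nc1sc2c(c1C(=O)NNc1ccccc1)CCCCCC2`: 43%
Compound 3 `NC(=O)c1c(N)sc2c1CCCCCC2`: 48%

Three compounds sharing one core were measured in a functional assay on CHO cells for agonist activity at adenosine receptor A1 (Homo sapiens), read by ERK phosphorylation, tested at 10 uM; a lower number here means a weaker effect, a higher number a stronger effect of the compound at the concentration tested. Compound 3 stands level with compound 1 at the digits printed, and together they give the highest of the three numbers; its nearest neighbour is compound 1, no change at the digits printed from compound 1 to compound 3 (within the scatter), and its furthest is compound 2, a number 5 percentage points higher from compound 2 to compound 3 (within the scatter). The step from compound 1 to compound 2, a number 5 percentage points lower from compound 1 to compound 2 (within the scatter), also stayed within the scatter.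

Compound 4 `Cc1ccc(C(=O)c2c(N)sc3c2CCCCCC3)cc1` differs from compound 3 in one place: 4-methylphenyl in place of amino on a carbonyl carbon. Going by the values given here, none of the measured steps touches the carbonyl carbon itself; all three only vary the group on the amide-type nitrogen, and each stayed within the scatter. The nearest analogy is the entry of a phenyl in the step from compound 1 to compound 2, which moved the number little. On that basis no step beyond the scatter is expected, a number 3 percentage points lower from compound 3 to compound 4 (within the scatter). Compound 4 is expected to give about 45% in this assay, within a range from 25% to 65%.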

Compound 4, a percentage reported as activity, at one concentration (the size of the read-out at that concentration, not a potency): 75%
Estimate against measurement, compound 4: 30 percentage points below; measured number outside the range, above it.
By their numbers in this assay, from the lowest: compounds 2, 1 and 3 (each within the scatter of the next); then compound 4.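

In this assay the group on the carbonyl carbon turns out to be a place where the read-out moves: 4-methylphenyl in place of amino gives a number 27 percentage points higher from compound 3 to compound 4 (beyond the scatter) and 4-methylphenyl in place of aminoamino gives a number 27 percentage points higher from compound 1 to compound 4 (beyond the scatter) on the shared core. Going by these compounds alone, the earlier compounds varied only the group on the amide-type nitrogen, and all their steps stayed within the scatter, so these two are the only steps here beyond it. No measurement available bears on why this change raises the number. Going by these compounds, it remains open whether the ring or its methyl carries the step, and whether a plain phenyl, a 4-methoxyphenyl or a cyclohexyl on the carbonyl carbon would give a similar number.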